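The source may hold more compounds than are shown below. What is called first, only, known or untested is meant among the compounds shown, and "the series" means these compounds.

Working notes on the series, read in a functional assay on SMMC-7721 cells (Homo sapiens) for inhibition, read by CCK-8 assay, with a stated time of 72 h, tested at 8 uM; on this read-out lower numbers stand for less inhibition of growth and higher numbers for more inhibition of growth at the one concentration tested. Compound 1 `Nc1ccccc1NC(=O)c1ccc(CSc2cccc(F)c2)cc1` gives 83%. Compound 2 `Cc1ccc(SCc2ccc(C(=O)Nc3ccccc3N)cc2)cc1` gives 82.7%, and the gap is small: a number 0.3 percentage points lower from compound 1 to compound 2 (within the scatter). Compound 3 `Nc1ccccc1NC(=O)c1ccc(CSc2ccc(Br)cc2)cc1` gives 25.3%, the lowest of the three numbers. The two steps that end at it are large: a number 57.7 percentage points lower from compound 1 to compound 3 (beyond the scatter) and a number 57.4 percentage points lower from compound 2 to compound 3 (beyond the scatter).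

Compound 4 `Nc1ccccc1NC(=O)c1ccc(CSCCc2ccccc2)cc1` carries phenethyl in place of 4-bromophenyl on a sulfur. Among the measured compounds shown here, no measured step puts a chain of this kind on the sulfur, so the three steps bear on the change only indirectly. For the measured compounds named here, both large steps end at compound 3, the one member carrying 4-bromophenyl, and this suggests that losing that group may recover much of the drop, as a number 57.4 percentage points lower from compound 2 to compound 3 (beyond the scatter) shows its size. A rise beyond the scatter is therefore expected in this assay, probably smaller than those large steps, with low confidence. For compound 4 the estimated step is a number 34.7 percentage points higher from compound 3 to compound 4 (beyond the scatter). Compound 4 is expected at 60%, within an estimated range of 25% to 88%.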

Compound 4, percent growth inhibition at one concentration: 77.9%
Compound 4: the middle estimate sits 17.9 percentage points below what was measured, within the range that was stated.
By their numbers in this assay, from the lowest: compound 3; then compounds 4, 2 and 1 (each within the scatter of the next).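

In this assay, phenethyl in place of 4-bromophenyl on the sulfur brings the large step (a number 52.6 percentage points higher from compound 3 to compound 4 (beyond the scatter)), so the low number of compound 3 does not carry over to this group. Phenethyl also stands level with the two other groups that give high numbers at this position (a number 4.8 percentage points lower from compound 2 to compound 4 (within the scatter); a number 5.1 percentage points lower from compound 1 to compound 4 (within the scatter)), which leaves 4-bromophenyl as the only group of the four with a low number. Nothing measured here accounts for that low number of compound 3.

On these data alone, it remains open whether chloro in place of bromo would keep the low number of compound 3. Also open, as far as these compounds go, is how other groups on the sulfur, such as a longer chain, an amine or a carboxylic acid, would read at this single concentration.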